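A few compounds are considered here, and "the series" means these few. Any claim that something is new, unique, unknown or untested is made for them only; others in the source may bear on it.

Compound 1, `CCOCCC(=O)NCC(=O)N[C@@H]1[C@@H](O)[C@H](O)[C@@H](Nc2ncnc3[nH]cnc23)O[C@H]1C`, is the starting point. In a functional assay on L1210 cells (Mus musculus) for inhibition, with a stated time of 3 h (a higher number here means that more compound is needed for the effect, a lower number that less compound is needed), compound 1 gives > 1000 uM, which is a limit of the assay rather than a number. Where compound 1 stands among the three measured compounds is therefore set by the limit of > 1000 uM in this assay, at which 2 of the 3 values shown sit. Compound 2, `CCCCCCCCCCCC(=O)NCC(=O)N[C@@H]1[C@@H](O)[C@H](O)[C@@H](Nc2ncnc3[nH]cnc23)O[C@H]1C`, gives 18 uM in this assay. Compound 3, `CCCCCC(=O)NCC(=O)N[C@@H]1[C@@H](O)[C@H](O)[C@@H](Nc2ncnc3[nH]cnc23)O[C@H]1C`, gives > 1000 uM in this assay, again a limit. The measured steps all concern the chain: an at least 55-fold lower number from compound 1 to compound 2 (1.74 log units; beyond the scatter), an at least 55-fold higher number from compound 2 to compound 3 (1.74 log units; beyond the scatter), and a step that the two limits leave unreadable from compound 1 to compound 3.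

Compound 4, `CCOCCC(=O)NCC(=O)N[C@@H]1[C@@H](O)[C@H](O)[C@@H](Nc2ncnc3[nH]cnc23)O[C@H]1CO`, differs from compound 1 by hydroxy in place of hydrogen on a saturated chain carbon bound to a saturated ring carbon. No measured step touches this part of the core; the three steps shown change only the chain. Compound 1 sits at a limit, so the step to compound 4 is expected to be one of no readable size, a number no higher from compound 1 to compound 4 (the limit leaves the size open). Compound 4 is therefore estimated to give about 1000 uM in this assay, most likely again as a limit, with a range from 300 uM to 3000 uM.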

Compound 4, concentration for half-maximal effect: > 1000 uM
Compound 4: a limit, no number; the forecaster's own chance of this, stated with the estimate: 85%; the middle value sits exactly at the limit.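

No step can be read between compound 1 and compound 4, because both stand at a limit: the limit of > 1000 uM in this assay, at which 3 of the 4 values shown sit. As far as these compounds go, what hydroxy in place of hydrogen on a saturated chain carbon bound to a saturated ring carbon does to the number in this assay remains open.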